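A few compounds are considered here, and "the series" means these few. Any claim that something is new, unique, unknown or untested is made for them only; others in the source may bear on it.

Measured compounds:

Compound 1, `CCCCC[Se]c1nc(NCc2ccccc2)c2ccccc2n1`: 34500 nM
Compound 2, `[SeH]c1nc(NCc2ccccc2)c2ccccc2n1`: a limit of the assay, > 100000 nM
Compound 3, `Nc1nc([SeH])nc2ncccc12`: 30900 nM

These values come from a functional assay on CCRF-CEM cells (Homo sapiens) for cytotoxicity, read by MTT assay, with a stated time of 72 h; a higher number here means a weaker inhibitor of growth, a lower number a stronger inhibitor of growth. Compound 2 reaches only a limit there, > 100000 nM, and no number. Compound 1 gives 34500 nM, and compound 3 gives 30900 nM. Between compound 2 and compound 1 one change is made, (pentyl in place of hydrogen on a selenium), and it produces an at least 2.8-fold lower number from compound 2 to compound 1 (0.46 log units; beyond the scatter). That step is known only as a bound, because compound 2 sits at the limit of > 100000 nM in this assay, at which 1 of the 3 values shown sits. Compound 3 has a different core from compound 2; the difference between the two cores is not broken down here.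

Compound 4, `CCCCC[Se]c1nc(N)c2cccnc2n1`, has not yet been measured in this assay. Among the measured compounds shown here, it arises from compound 3 by pentyl in place of hydrogen on a selenium, which is the same change as the one from compound 2 to compound 1: the selenium that carries the pentyl has the same neighbour in both pairs, an aromatic carbon. Compound 3 and compound 1 give numbers within the scatter of each other, so the two parent compounds start from a similar place.

For compound 4 in this assay the expected step is a 2.6-fold lower number from compound 3 to compound 4 (0.41 log units; beyond the scatter), resting on the step from compound 2 to compound 1, an at least 2.8-fold lower number from compound 2 to compound 1 (0.46 log units; beyond the scatter), which is a bound and so leaves the true size open. On that basis compound 4 is expected to give about 12000 nM, estimated to lie between 4000 nM and 40000 nM.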

Compound 4, concentration for 50% growth inhibition: 12900 nM
Beside the measured number, compound 4's estimate is 1.1-fold (0.03 log units) below it; the measured number falls inside the stated range.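

In this assay, pentyl in place of hydrogen on the selenium gives a 2.4-fold lower number from compound 3 to compound 4 (0.38 log units; beyond the scatter), so the number falls on this second core too, by more than the scatter. Set beside the earlier case, the change points the same way on both cores, which is what makes it look transferable within this small set: the same change on two cores in this assay, an at least 2.8-fold lower number (0.46 log units; beyond the scatter) from compound 2 to compound 1 and a 2.4-fold lower number (0.38 log units; beyond the scatter) from compound 3 to compound 4; the limit leaves it open whether they differ. What this does not show is that the change is worth one fixed amount wherever it is made, or that it would hold on a third core, since the earlier step is known only as a bound and two pairs are a thin basis: the limit of > 100000 nM in this assay, at which 1 of the 4 values shown sits.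

Pentyl is the only group on the selenium other than hydrogen among the compounds shown, so it stays open how the number would respond to a shorter chain such as methyl, a longer chain such as octyl, or a ring-bearing group such as benzyl. Going by these compounds, it also stays open whether the step would survive on a core carrying a different group elsewhere, such as a carboxylic acid.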